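Swapping the para substituent on the aryl ether of compound 2

The source may report more compounds than this note shows. Statements on the series, on what has been measured and on what is new or still open speak of the compounds shown alone.

The three measured compounds share one core and differ only in the aromatic ring carried on the oxygen on a saturated carbon. In an in vitro assay on HEK293 cells with metabotropic glutamate receptor 2 (Rattus norvegicus) as the target, read by FLIPR, in the presence of a further agent that is not named here (a higher number here means that more compound is needed for the effect, a lower number that less compound is needed), compound 1 `Cn1c(CN2C[C@@H]3C(COc4cc(F)ccc4F)[C@@H]3C2)nc2ccccc21` gives 7 nM, compound 3 `Cn1c(CN2C[C@@H]3C(COc4ccc(Cl)cc4F)[C@@H]3C2)nc2ccccc21` gives 8 nM, and compound 2 `CC(C)c1ccc(OCC2[C@H]3CN(Cc4nc5ccccc5n4C)C[C@@H]23)cc1` gives 26 nM, the highest of the three numbers. The steps to compound 2 are a 3.7-fold higher number from compound 1 to compound 2 (0.57 log units; beyond the scatter) and, in the other direction, a 3.3-fold lower number from compound 2 to compound 3 (0.51 log units; beyond the scatter), while a 1.1-fold higher number from compound 1 to compound 3 (0.06 log units; within the scatter).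

Compound 4 `Cn1c(CN2C[C@@H]3C(COc4ccc(C(F)(F)F)cc4)[C@@H]3C2)nc2ccccc21` is compound 2 with trifluoromethyl in place of isopropyl on an aromatic carbon. Going by the values given here, no measured pair exchanges a trifluoromethyl for an isopropyl, so the bearing of the measured steps is indirect: both rings that replace the isopropylphenyl give lower numbers by a modest margin. A similar modest lowering is therefore expected, so that this assay should show a 2.2-fold lower number from compound 2 to compound 4 (0.34 log units; beyond the scatter). For compound 4 the estimate in this assay is 12 nM, with a range from 4 nM to 40 nM.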

Compound 4, half-maximal effective concentration: 85 nM
Compound 4: middle estimate off by 7.1-fold (0.85 log units), on the low side; the whole stated range lies below it.
By their numbers in this assay, from the lowest: compounds 1 and 3 (each within the scatter of the next); then compound 2; then compound 4.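

Exchanging the group on this aromatic carbon does not always lower the number: trifluoromethyl in place of isopropyl gives a 3.3-fold higher number from compound 2 to compound 4 (0.51 log units; beyond the scatter) in this assay, the opposite direction from both earlier replacements of the 4-isopropylphenyl ring. The isopropyl and trifluoromethyl groups have the same counts of hydrogen-bond donors, acceptors and net charge, so these counts do not predict the number at this position. Compound 4 now has the highest number of the four, so the series spans a wider range through a change of a single group. No measurement shown here accounts for this step.

The compounds shown leave open how a methoxy group or a nitrile on the same aromatic carbon would compare with isopropyl and trifluoromethyl. They also leave open whether adding fluorine to the trifluoromethyl-bearing ring of compound 4 would change its number.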